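This account rests on a few compounds, and the source may have more. Where it says the series, first, only, none or still open, it means among the compounds named here.

Among the compounds with values here, in a functional assay on OVCAR-3 cells (Homo sapiens) for antiproliferative activity, read by MTT assay, with a stated time of 24 h (on this read-out lower numbers stand for stronger inhibition and higher numbers for weaker inhibition), compound 3 `CCCCOc1ccc(C(=O)NNC(=O)c2ccc(NS(=O)(=O)c3cnc(O)nc3O)cc2)cc1` gives 12800 nM, the only real number among the three compounds measured. Compound 1 `Cc1cccc(NNC(=O)c2ccc(NS(=O)(=O)c3cnc(O)nc3O)cc2)c1` reaches only a limit of the assay, > 20000 nM. Compound 2 `O=C(NNc1ccc(F)cc1)c1ccc(NS(=O)(=O)c2cnc(O)nc2O)cc1` likewise gives only a limit, > 20000 nM. Compound 4 `Cc1ccccc1C(=O)NNC(=O)c1ccc(NS(=O)(=O)c2cnc(O)nc2O)cc1` carries 2-methylphenyl in place of 4-butoxyphenyl on a carbonyl carbon. Within the data shown here, the only measured step, a step that the two limits leave unreadable from compound 1 to compound 2, concerns different groups and offers no size to carry over. With the limit of > 20000 nM in this assay, at which 2 of the 3 values shown sit, compound 4 may well report a limit too. The estimate therefore starts from compound 3 at 12800 nM. The expected step, a 1.3-fold higher number from compound 3 to compound 4 (0.12 log units; within the scatter), is estimated to stay within the usual scatter. For compound 4, the expected value is 17000 nM, with an estimated range from 8000 nM to 35000 nM.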

Compound 4, half-maximal inhibitory concentration: > 20000 nM
Compound 4: only a limit was reported (the forecaster's own chance of this, stated with the estimate: 50%); at least 1.1-fold (0.07 log units) between middle value and limit.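

Within the data shown here, at this place on a carbonyl carbon, 2-methylphenyl in place of 4-butoxyphenyl gives an at least 1.5-fold higher number from compound 3 to compound 4 (0.19 log units; that floor lies within the scatter), the first step with a readable floor. The value of compound 4 is only a limit, so the true step may be larger, but the floor alone does not separate it from scatter. The steps from compound 1 and compound 2 to compound 4 cannot be read.

Going by these compounds, how a longer chain than butoxy, or an amine, would read at this place stays open. Little can be ranked in this assay: the limit of > 20000 nM in this assay, at which 3 of the 4 values shown sit.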